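Ribose series: cinnamyl to carbamoylmethyl on the shared core

A few compounds are considered here, and "the series" means these few. Any claim that something is new, unique, unknown or untested is made for them only; others in the source may bear on it.

Measured so far:
compound 1 `Nc1nc(O)c2c(n1)n(C1OC(CO)[C@@H](O)[C@H]1O)c(=O)n2C/C=C/c1ccccc1` gives 73%
compound 2 `C=CCn1c(=S)n(C2OC(COCc3ccccc3)[C@H]3OC(C)(C)O[C@@H]23)c2nc(N)nc(O)c21` gives 77%
compound 3 `C=CCn1c(=O)n(CCCCCCCC)c2nc(N)nc(O)c21` gives 130%

All three numbers come from a functional assay on the whole organism (B cells) with Mus musculus as the target; on this read-out lower numbers stand for smaller maximal responses and higher numbers for larger maximal responses. Compound 1 and compound 2 sit within the usual scatter of each other, so nothing separates them. Compound 3 stands apart: its value lies beyond the scatter above compound 1 and above compound 2.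

Compound 4 `NC(=O)Cn1c(=O)n(C2OC(CO)[C@@H](O)[C@H]2O)c2nc(N)nc(O)c21` has not been measured. It keeps the sugar and the core of compound 1 and differs in one place: carbamoyl in place of 2-phenylethenyl on a saturated chain carbon bound to an aromatic nitrogen. Among the compounds with values here, no two measured compounds differ in just one place, so no measured step gives a direct guide for this change. The only large difference seen, between compound 1 and compound 3, involves several changes at once and cannot be assigned to any single one of them.

With that in mind, the expectation for compound 4 in this assay is a step of no clear direction beyond the scatter, a number 3 percentage points lower from compound 1 to compound 4 (within the scatter). The estimated value for compound 4 is 70%, within a range from 40% to 110%.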

Compound 4, largest response reached (reported as maximal response), in percent of the reference or control that the assay uses: 32%
Compound 4: the middle estimate sits 38 percentage points above what was measured, and the stated range ends above it.
By their numbers in this assay, from the lowest: compound 4; then compounds 1 and 2 (each within the scatter of the next); then compound 3.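

In this assay the series gains its first single-place step, a number 41 percentage points lower from compound 1 to compound 4 (beyond the scatter), showing that with the sugar and the shared core held fixed, the group at this place bears on the maximal response. Carbamoyl in place of 2-phenylethenyl removes the six-membered aromatic ring, reduces the group from 8 heavy atoms to 3 and adds a hydrogen-bond donor and acceptor, so this single step cannot assign the fall to any one of these differences. No measurement at hand accounts for the fall.

The compounds shown leave open whether the fall follows the loss of the phenyl ring or the arrival of carbamoyl, and whether an amine, a carboxylic acid or a longer chain at this place would read closer to compound 1 or compound 4. Also open, going by these compounds, is whether the same step would hold without the sugar.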